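The source may hold more compounds than are shown below. What is called first, only, known or untested is meant among the compounds shown, and "the series" means these compounds.

The measured compounds, each in an ADME assay on HeLa cells (Homo sapiens) for cytotoxicity, read by ATP content, with a stated time of 3 days; a higher number here means that more compound is tolerated, a lower number that less compound is tolerated:

Compound 1 `COc1ccc(-n2c(=O)n(Cc3cc4cc(Cl)ccc4n3CCCC#N)c3cnccc32)c(F)c1` gives > 50000 nM, which is a limit of the assay and not a number.
Compound 2 `O=c1n(Cc2cc3cc(Cl)ccc3n2CCCC(F)(F)F)c2cnccc2n1C1CC1` gives > 50000 nM, again a limit of the assay.
Compound 3 `CS(=O)(=O)CCCn1c(Cn2c(=O)n(C3CC3)c3ccncc32)cc2ccccc21` gives > 100000 nM, also a limit of the assay.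

Compound 1 therefore stands at a limit rather than at a measured number in this assay. Across the set, two of the three values rest at the limit of > 50000 nM in this assay, at which 2 of the 3 values shown sit, and the third at the limit of > 100000 nM in this assay, at which 1 of the 3 values shown sits, so no compound here has yielded a number at all.

Compound 4 `N#CCCCn1c(Cn2c(=O)n(-c3ccc(C(=O)NC4CC4)cc3)c3ccncc32)cc2cc(Cl)ccc21` differs from compound 1 by 4-(cyclopropylcarbamoyl)phenyl in place of 2-fluoro-4-methoxyphenyl on an aromatic nitrogen. Going by the values given here, no step between measured compounds is available to gauge the size of such a change in this assay. Since compound 1 sits at a limit in this assay, the change from compound 1 to compound 4 is expected to produce no step beyond the usual scatter. The expected step is thus a step that the limit leaves unreadable from compound 1 to compound 4. Compound 4 is expected to give 60000 nM in this assay, with a range from 20000 nM to 150000 nM, and most likely to be reported once more as a limit.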

Compound 4, half-maximal cytotoxic concentration: > 50000 nM
Compound 4: only a limit was reported (the forecaster's own chance of this, stated with the estimate: 80%); the middle value is on the limit's open side.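

Going by these compounds alone, compound 1 and compound 4 both stand at a limit of the assay rather than at a number, so no step between them can be read in this assay. The compounds shown leave open where any of their true values lie: the limit of > 50000 nM in this assay, at which 3 of the 4 values shown sit.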